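Ethyl to piperidin-1-yl on a sulfonyl sulfur

A few compounds are considered here, and "the series" means these few. Any claim that something is new, unique, unknown or untested is made for them only; others in the source may bear on it.

Measured in a functional assay on MDA-MB-231 cells (Homo sapiens) for antiproliferative activity, read by MTT assay, with a stated time of 48 h; on this read-out higher numbers stand for weaker inhibition and lower numbers for stronger inhibition:
- compound 1 `CN1CCN(c2ccc(-c3cc4c(N5CCN(S(=O)(=O)/C=C/c6ccccc6)CC5)ncnc4s3)cc2)CC1` gives 5900 nM
- compound 2 `CCS(=O)(=O)N1CCN(c2ncnc3sc(-c4ccc(N5CCN(C)CC5)cc4)cc23)CC1` gives 7330 nM

For the measured compounds named here, on these two numbers, compound 2 at 7330 nM cannot be told apart from compound 1, as the one measured step shows: a 1.2-fold higher number from compound 1 to compound 2 (0.09 log units; within the scatter). The next compound, compound 3 `CN1CCN(c2ccc(-c3cc4c(N5CCN(S(=O)(=O)N6CCCCC6)CC5)ncnc4s3)cc2)CC1`, carries piperidin-1-yl in place of ethyl on a sulfonyl sulfur. The measured step bears directly on this change, since it exchanged 2-phenylethenyl for ethyl on the same sulfur and stayed within the scatter. On that single step, no change beyond the scatter is expected in this assay. Neither measured compound carries piperidin-1-yl there, so the range is kept wide. The expected step is a 1.1-fold lower number from compound 2 to compound 3 (0.05 log units; within the scatter). Compound 3 is estimated at 6500 nM, with an expected range of 2500 nM to 15000 nM.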

Compound 3, half-maximal inhibitory concentration: 8130 nM
Estimate against measurement, compound 3: 1.3-fold (0.10 log units) below, and the stated range covers the measured number.
By their numbers in this assay, from the lowest: compounds 1, 2 and 3 (each within the scatter of the next).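

In this assay the step reads a 1.1-fold higher number from compound 2 to compound 3 (0.04 log units; within the scatter) for ethyl exchanged for piperidin-1-yl on the sulfonyl sulfur and a 1.4-fold higher number from compound 1 to compound 3 (0.14 log units; within the scatter) for 2-phenylethenyl exchanged for the same group. A six-membered non-aromatic ring with one hetero atom, the third kind of group at this place, therefore also stays within the scatter, and compounds 1, 2 and 3 cannot be told apart here, though the group that enters has more heavy atoms than ethyl. No measurement shown gives a reason for this result.

Still open, as far as these compounds go, is whether a group ending in a primary amine or a carboxylic acid on this sulfur would move the number beyond the scatter. All three compounds also share the rest of the structure, so they say nothing about changes elsewhere on the core.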